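The source may hold more compounds than are shown below. What is called first, only, known or untested is meant among the compounds shown, and "the series" means these compounds.

Measured in a functional assay on PC-3 cells (Homo sapiens) for inhibition, read by sulforhodamine B assay, with a stated time of 72 h; on this read-out lower numbers stand for stronger inhibition and higher numbers for weaker inhibition:
compound 1 `Nc1sc(-c2ccc(Cl)cc2)c(-c2ccc(Cl)cc2)c1C(=O)N1CCCCC1=O`: 4940 nM
compound 2 `Nc1sc(-c2ccc(Cl)cc2)c(-c2ccc(Cl)cc2)c1C(=O)NC1CCCCC1`: 7300 nM
compound 3 `CC(C)CNC(=O)c1c(N)sc(-c2ccc(Cl)cc2)c1-c1ccc(Cl)cc1`: 13200 nM

The place of compound 3 in this short series is set by two steps: a 1.8-fold higher number from compound 2 to compound 3 (0.26 log units; within the scatter), and a 2.7-fold higher number from compound 1 to compound 3 (0.43 log units; beyond the scatter). Compound 4 `Nc1sc(-c2ccc(Cl)cc2)c(-c2ccc(Cl)cc2)c1C(=O)NCc1ccccc1` has not yet been measured. It differs from compound 3 by phenyl in place of isopropyl on a saturated chain carbon bound to an amide-type nitrogen, which is phenyl in place of isopropyl on a saturated chain carbon bound to an amide-type nitrogen. Among the compounds with values here, no measured compound makes this exact change. Within the data shown here, the nearest precedent is the exchange of cyclohexyl for isobutyl on the amide-type nitrogen, which links a ring-bearing amide, compound 2, to a ring-free one: a 1.8-fold higher number from compound 2 to compound 3 (0.26 log units; within the scatter). On that basis, only a small step is expected in this assay, towards a lower number if it shows at all, and probably not beyond the scatter. The estimated step is a 1.4-fold lower number from compound 3 to compound 4 (0.14 log units; within the scatter). For compound 4 the expected value is 9500 nM, with an estimated range of 4500 nM to 20000 nM.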

Compound 4, half-maximal inhibitory concentration: 31800 nM
Estimate against measurement, compound 4: 3.3-fold (0.52 log units) below, and the stated range ends below it.
By their numbers in this assay, from the lowest: compounds 1, 2 and 3 (each within the scatter of the next, the first and the last beyond it); then compound 4.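

In this assay, the phenyl in place of isopropyl on a saturated chain carbon bound to an amide-type nitrogen gives a 2.4-fold higher number from compound 3 to compound 4 (0.38 log units; beyond the scatter) and so moves the number beyond the scatter, whereas the earlier exchange of cyclohexyl for isobutyl stayed within it. Benzyl also stands apart from the other two groups at this place, with a 4.4-fold higher number from compound 2 to compound 4 (0.64 log units; beyond the scatter) for benzyl in place of cyclohexyl and a 6.4-fold higher number from compound 1 to compound 4 (0.81 log units; beyond the scatter) for benzylamino in place of 2-oxopiperidin-1-yl, which leaves compound 4 the weakest of the four. The data shown offer no evidence that accounts for this step.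

The compounds shown leave open whether phenethyl, with a longer chain to the phenyl, would follow benzyl or return towards isobutyl. They also leave open how pyridylmethyl, with a ring nitrogen, would compare with benzyl.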